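Swapping the Aryl Group on the Ring Nitrogen

The source may report more compounds than this note shows. Statements on the series, on what has been measured and on what is new or still open speak of the compounds shown alone.

Measured so far in a functional assay on HCT-116 cells (Homo sapiens) for cytotoxicity, read by sulforhodamine B assay, with a stated time of 48 h; on this read-out lower numbers stand for stronger inhibition and higher numbers for weaker inhibition:
compound 1 `CO[C@@H]1CC=C2NN(c3ccc(C)cc3)C(=O)CC[C@]2(c2ccccc2)O1`, 2500 nM;
compound 2 `CO[C@@H]1CC=C2NN(c3ccccn3)C(=O)CC[C@]2(c2ccccc2)O1`, 1400 nM;
compound 3 `CO[C@@H]1CC=C2N(c3ccc([N+](=O)[O-])cc3)C(=O)C[C@]2(c2ccccc2)O1`, 8000 nM.

Compound 3 gives the highest number of the three, a weaker inhibition than either compound 1 or compound 2, and both gaps lie beyond the scatter. Compound 4 `CO[C@@H]1CC=C2N(c3cc(Cl)cc(Cl)c3)C(=O)C[C@]2(c2ccccc2)O1` differs from compound 3 in one place: 3,5-dichlorophenyl in place of 4-nitrophenyl on an amide-type nitrogen in a ring. Among the compounds with values here, the only measured step, a 1.8-fold lower number from compound 1 to compound 2 (0.25 log units; within the scatter), also replaces the aryl group on the ring nitrogen, though on a different core, and it stayed within the scatter. Within the data shown here, no measured step bears directly on the change in compound 4. For compound 4 the expected step is therefore a 1.3-fold lower number from compound 3 to compound 4 (0.12 log units; within the scatter), nothing beyond the scatter. Compound 4 is expected at 6000 nM, with a range from 2000 nM to 20000 nM.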

Compound 4, half-maximal inhibitory concentration: 11200 nM
Compound 4: the middle estimate sits 1.9-fold (0.27 log units) below what was measured; the measured number falls inside the stated range.
By their numbers in this assay, from the lowest: compounds 2 and 1 (each within the scatter of the next); then compounds 3 and 4 (each within the scatter of the next).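

In this assay the step of a 1.4-fold higher number from compound 3 to compound 4 (0.15 log units; within the scatter) shows that, on the ring nitrogen of this shared core, 3,5-dichlorophenyl and 4-nitrophenyl cannot be told apart. The number stays put even though a group carrying hydrogen-bond acceptors gives way to one carrying none. Nothing available explains why these two aryl groups read alike.

Still open, on these data alone, is whether a ring bearing an amine or a carboxylic acid would move the number beyond the scatter. A plain methyl in place of the aryl group is equally untested among the compounds shown.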